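This account rests on a few compounds, and the source may have more. Where it says the series, first, only, none or still open, it means among the compounds named here.

Compound 1 `CC(C)=CCC/C(C)=C/CCC1=C[C@H](c2ccccc2)OC1=O` gives 16500 nM in an assay on microsomes from liver for inhibition of 3-hydroxy-3-methylglutaryl-coenzyme A reductase (Sus scrofa), read by colorimetric assay; on this read-out higher numbers stand for weaker inhibition and lower numbers for stronger inhibition.
Compound 2 `CC(C)=CCC/C(C)=C/CCC1=C[C@H](c2ccc(C(C)(C)C)cc2)OC1=O` gives 5820 nM in this assay.

Among these two numbers compound 1 stands highest; its nearest neighbour is compound 2, reached by a 2.8-fold lower number from compound 1 to compound 2 (0.45 log units; beyond the scatter), the only measured step, and a modest one.

Compound 3 `CC(C)=CCC/C(C)=C/CCC1=C[C@H](c2cc(F)ccc2F)OC1=O` is reached from compound 1 by 2,5-difluorophenyl in place of phenyl on a saturated ring carbon. Going by the values given here, no measured step alters the phenyl in this way: the single step from compound 1 to compound 2 puts a tert-butyl group on the aromatic ring, a change of a different kind, so it bears only loosely on the present one. What it does show is that a change on the phenyl ring of compound 1 moved the number by a 2.8-fold lower number from compound 1 to compound 2 (0.45 log units; beyond the scatter), without a large jump in either direction. On that basis the change to compound 3 is expected to bring a small step at most, likely towards a lower number, with a fair chance of staying within the scatter.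

The estimate for compound 3 is 10000 nM, with a range from 4000 nM to 25000 nM, which means an expected step of a 1.7-fold lower number from compound 1 to compound 3 (0.22 log units; within the scatter).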

Compound 3, half-maximal inhibitory concentration: 25100 nM
Estimate against measurement, compound 3: 2.5-fold (0.40 log units) below, and the stated range ends below it.
By their numbers in this assay, from the lowest: compound 2; then compounds 1 and 3 (each within the scatter of the next).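

In this assay, placing 2,5-difluorophenyl instead of phenyl on the saturated ring carbon next to the ring oxygen gives a 1.5-fold higher number from compound 1 to compound 3 (0.18 log units; within the scatter) and so produces no readable change in the number at this site. The earlier step, a 2.8-fold lower number from compound 1 to compound 2 (0.45 log units; beyond the scatter) and thus the only one of the two beyond the scatter, had shown that a change on this phenyl can lower the number, and the new result shows that not every change on it does: of the two substitutions seen here, tert-butyl moves the number and the two fluorine atoms do not. Nothing measured here accounts for the difference between these two changes.

The compounds shown leave open whether a single fluorine, a methoxy group, an amine or a carboxylic acid on this phenyl ring would shift the number beyond the scatter in either direction. They also leave open whether a tert-butyl group combined with fluorine on the same ring would keep the lower number seen for compound 2 or lose it.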